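The compounds below may be only part of what the source reports. "The series", "measured", "known", "first", "only" and "open" are said of these compounds alone.

Measured so far in a functional assay for antagonist activity at transient receptor potential cation channel subfamily V member 1 (Rattus norvegicus); on this read-out higher numbers stand for weaker inhibition and lower numbers for stronger inhibition:

Compound 1, `Cc1cccnc1-c1ccc(C(=O)Nc2ccc(C(C)C)cc2)cc1`, gives 43 nM.
Compound 2, `Cc1cccnc1-c1ccc(C(=O)Nc2ccc(C(F)(F)F)cc2)cc1`, gives 81 nM.
Compound 3, `CCCNc1cccnc1-c1ccc(C(=O)Nc2ccc(C(C)(C)C)cc2)cc1`, gives 37 nM.

Compound 3 gives the smallest of the three numbers, but its distance from compound 1 lies within the usual scatter, and only its distance from compound 2 lies beyond it. Within the data shown here, the one measured step, a 1.9-fold higher number from compound 1 to compound 2 (0.28 log units; within the scatter), concerns a change on the other end of the shared core, not the place that changes next.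

Compound 4, `Cc1nnc(-c2cccnc2-c2ccc(C(=O)Nc3ccc(C(C)(C)C)cc3)cc2)o1`, differs from compound 3 in one place: 5-methyl-1,3,4-oxadiazol-2-yl in place of propylamino on an aromatic carbon. Among the measured compounds shown here, no measured step touches this position, so there is nothing here to show how far a change there moves the number; the two measured changes at other places moved it little or within the scatter. For the measured compounds named here, with that as the only guide, no step beyond the scatter is expected in this assay, in either direction. Compound 4 is therefore estimated at 45 nM, between 15 nM and 140 nM. That amounts to an expected step of a 1.2-fold higher number from compound 3 to compound 4 (0.09 log units; within the scatter), within the scatter.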

Compound 4, half-maximal inhibitory concentration: 34 nM
Compound 4: the middle estimate sits 1.3-fold (0.12 log units) above what was measured, and the stated range covers the measured number.
By their numbers in this assay, from the lowest: compounds 4, 3, 1 and 2 (each within the scatter of the next, the first and the last beyond it).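

Among these compounds, this is the first measured step at this position, on an aromatic carbon two atoms from the ring nitrogen, and in this assay it is small (a 1.1-fold lower number from compound 3 to compound 4 (0.04 log units; within the scatter)). The change itself is large on paper: propylamino, a chain with no ring and one hydrogen-bond donor, gives way to 5-methyl-1,3,4-oxadiazol-2-yl, a five-membered aromatic ring with no donor, yet the number stays within the scatter, so this pair shows that the position can carry either group with no measurable change in this read-out. Nothing available here explains why two such different groups read alike.

As far as these compounds go, whether that holds for other kinds of group at this position, such as a carboxylic acid or a simple primary amine, stays open. Also open, from the compounds shown here alone, is whether it would hold with isopropyl or trifluoromethyl at the other end of the shared core.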